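The compounds below may be only part of what the source reports. "The series", "measured", "known", "first", "only" and "open" are said of these compounds alone.

Values measured so far in a functional assay on HCC 2998 cells (Homo sapiens) for antiproliferative activity (on this read-out lower numbers stand for stronger inhibition of growth and higher numbers for weaker inhibition of growth), are as follows

- compound 1 `COc1ccc(-c2nc3cc(F)ccc3s2)cc1` gives 12400 nM
- compound 2 `COc1ccc(-c2nc3cc(F)ccc3s2)cc1F` gives 13700 nM
- compound 3 `COc1ccc(-c2nc3cc(F)ccc3s2)cc1Cl` gives 2500 nM

Compound 3 has the lowest number of the three, and its gaps to compound 1 and compound 2 both lie beyond the scatter. Next is compound 4 `COc1ccc(-c2nc3cc(F)ccc3s2)cc1Br`, still unmeasured. It keeps the shared core and the methoxy group and differs from compound 3 by one substituent: bromo in place of chloro on an aromatic carbon (bromo in place of chloro on an aromatic carbon, ortho to a methoxy group).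

Three measured steps at this same carbon bear on the change. Fluoro in place of hydrogen gave a 1.1-fold higher number from compound 1 to compound 2 (0.04 log units; within the scatter), whereas chloro in place of hydrogen gave a 5.0-fold lower number from compound 1 to compound 3 (0.70 log units; beyond the scatter), and chloro in place of fluoro gave a 5.5-fold lower number from compound 2 to compound 3 (0.74 log units; beyond the scatter) as a similar modest move. No bromo has been measured in this series, so the size of the swap is not directly known. Bromo is expected to track chloro rather than fluoro, which makes compound 3 at 2500 nM the best anchor. In this assay the expected change is a 1.1-fold lower number from compound 3 to compound 4 (0.04 log units; within the scatter) and no shift beyond the scatter is anticipated. The estimate for compound 4 is 2300 nM, with an expected range from 900 nM to 6000 nM.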

Compound 4, concentration for 50% growth inhibition: 3450 nM
The estimate for compound 4 lay 1.5-fold (0.18 log units) below the measured number; low and high end bracket the measured number.
By their numbers in this assay, from the lowest: compounds 3 and 4 (each within the scatter of the next); then compounds 1 and 2 (each within the scatter of the next).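

In this assay the swap to bromo on this aromatic carbon, ortho to a methoxy group, gives a 1.4-fold higher number from compound 3 to compound 4 (0.14 log units; within the scatter) and so leaves chloro and bromo indistinguishable at this position. Bromo also stands apart from the two smaller comparisons in the set, giving a 4.0-fold lower number from compound 2 to compound 4 (0.60 log units; beyond the scatter) and a 3.6-fold lower number from compound 1 to compound 4 (0.56 log units; beyond the scatter) as modest steps, so the lower numbers first seen with chloro alone now appear with a second substituent. Within the halogens shown, fluoro goes against this pattern, since compound 2 stays within the scatter of compound 1, and no information at hand accounts for the split between fluoro on one side and chloro and bromo on the other.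

Still open, on these data alone, is whether anything other than chloro or bromo at this carbon, such as iodo, a nitrile, an amine or a longer alkoxy chain, would give numbers as low as those of compound 3 and compound 4. Also open, as far as these compounds go, is whether the same order would hold if the methoxy group gave way to a hydroxyl group, or on cell lines other than this one.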